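Working notes on compounds 1 to 4

The source may report more compounds than this note shows. Statements on the series, on what has been measured and on what is new or still open speak of the compounds shown alone.

Measured so far:
- compound 1 `CCC(COc1cccc(Cl)c1)OC(=O)NCc1ccccc1`: a limit of > 100000 nM
- compound 2 `O=C(NCc1ccccc1)OCCOc1cccc(C(F)(F)F)c1`: a limit of > 100000 nM
- compound 3 `CC(COc1cccc(C(F)(F)F)c1)OC(=O)NCc1ccccc1`: a limit of > 100000 nM

All three were tested in an assay for inhibition of zeta-carotene desaturase, chloroplastic/chromoplastic (Capsicum annuum), using a Dixon plot, with a stated time of 8 h; a lower number here means a stronger inhibitor, a higher number a weaker inhibitor. None gives a number: each sits at the limit of > 100000 nM in this assay, at which 3 of the 3 values shown sit. Going by the values given here, the one paired change among them, (methyl in place of hydrogen on a saturated chain carbon bound to an oxygen next to a carbonyl group and a saturated chain carbon), is therefore unreadable, a step that the two limits leave unreadable from compound 2 to compound 3, since both ends are limits. How the core of compound 1 differs from the core of compound 2 is not broken down here.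

Compound 4 `CCC(COc1cccc(Cl)c1)OC(=O)NC(C)c1ccccc1` is the not yet measured member. It carries the same kind of change as the pair already tested, (methyl in place of hydrogen on a saturated chain carbon bound to an amide-type nitrogen and an aromatic carbon), though the place is not the same: here the saturated chain carbon is bound to an amide-type nitrogen and an aromatic carbon, whereas in the measured pair it is bound to an oxygen next to a carbonyl group and a saturated chain carbon.

Among the compounds with values here, with compound 1 at a limit and the only comparable step unreadable, nothing here points to a gain; the expectation for compound 4 is a step that the limit leaves unreadable from compound 1 to compound 4 in this assay. Compound 4 is expected at roughly 150000 nM, most likely reported again as a limit, within 30000 nM to 600000 nM.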

Compound 4, half-maximal inhibitory concentration: > 100000 nM
Compound 4 ended at the assay's limit; the forecaster's own chance of this, stated with the estimate: 85%; the middle value is on the limit's open side.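

No step can be read between compound 1 and compound 4, since both stand at a limit and not at a number: the limit of > 100000 nM in this assay, at which 4 of the 4 values shown sit.

The compounds shown leave open how large the change from benzyl to 1-phenylethyl is, and whether any compound of this series gives a measurable value in this assay.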